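Swapping One Chlorine for Two on the Sulfonyl Ring

The source may report more compounds than this note shows. Statements on the series, on what has been measured and on what is new or still open speak of the compounds shown alone.

Within the data shown here, compound 2 `CC1CCN(c2c(S(=O)(=O)c3ccc(Cl)cc3)cnc3c(F)cccc23)CC1` gives 85% in an assay on isolated protein for displacement of a labelled ligand from metabotropic glutamate receptor 5 (Homo sapiens), with a stated time of 60 min, tested at 1 uM (a higher number here means more inhibition at the concentration tested (going by the name of the read-out), a lower number less inhibition), which places it at the lower end of the two numbers measured so far, though the gap to its only neighbour is within the scatter. That neighbour, compound 1 `Cc1ccc(S(=O)(=O)c2cnc3c(F)cccc3c2N2CCC(C)CC2)cc1`, gives 93% in this assay, and the step of a number 8 percentage points lower from compound 1 to compound 2 (within the scatter) stays within the scatter. Compound 3 `CC1CCN(c2c(S(=O)(=O)c3cc(Cl)cc(Cl)c3)cnc3c(F)cccc23)CC1` differs from compound 2 by 3,5-dichlorophenyl in place of 4-chlorophenyl on a sulfonyl sulfur. Among the measured compounds shown here, no measured step changes that ring in this way, and the one step available was small, so nothing beyond the scatter is expected in this assay. Compound 3 is therefore estimated at 80%, between 55% and 95%, an expected step of a number 5 percentage points lower from compound 2 to compound 3 (within the scatter).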

Compound 3, a percentage reported as inhibition, at one concentration (the size of the read-out at that concentration, not a potency): 82%
Estimate against measurement, compound 3: 2 percentage points below; measured number inside the range.
By their numbers in this assay, from the lowest: compounds 3, 2 and 1 (each within the scatter of the next, the first and the last beyond it).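

Putting 3,5-dichlorophenyl in place of 4-chlorophenyl on the sulfonyl sulfur gives a number 3 percentage points lower from compound 2 to compound 3 (within the scatter) in this assay, so a ring with two chlorines is accepted here about as well as one with a single chlorine. Set against 4-methylphenyl, the same ring gives a number 11 percentage points lower from compound 1 to compound 3 (beyond the scatter), the only step so far to pass beyond the scatter, and still a modest one. Nothing available explains either step. Still open, going by these compounds, is how a methoxy group, a nitrile or an amine on this ring would compare, and whether a pyridine ring could replace it.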